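Cyano in Place of Methyl on a Side Chain

The compounds below may be only part of what the source reports. "The series", "measured", "known", "first", "only" and "open" are said of these compounds alone.

Measured compounds:
compound 1, `CCN(c1ccc(C(C)C)cc1)c1nc(C)cc(C)n1` — in an assay on isolated protein for binding affinity to corticotropin-releasing factor receptor 1 (Homo sapiens) (on this read-out lower numbers stand for stronger inhibition and higher numbers for weaker inhibition), compound 1 gives > 1000 nM, a limit of the assay
compound 2, `CCCN(CCC)c1nc(C)nc(N(CC)c2ccc(N(C)C)cc2C)n1` — in this assay compound 2 gives 7 nM

Going by the values given here, compound 2 holds the only actual number among the two values shown. Compound 1 sits at a limit of this assay, (the limit of > 1000 nM in this assay, at which 1 of the 2 values shown sits), so no number is known for it. Among the compounds with values here, no pair of measured compounds differing in one place is available, so the size of a single change has not yet been seen.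

Compound 3, `CCCN(CCC#N)c1nc(C)nc(N(CC)c2ccc(N(C)C)cc2C)n1`, is not yet measured. It differs from compound 2 as follows: cyano in place of methyl on a saturated chain carbon, two bonds along the chain from a nitrogen on an aromatic ring.

Within the data shown here, with no measured step to lean on, the expectation rests on compound 2 alone. A modest weakening, somewhat beyond the scatter, is expected from compound 2 to compound 3, a 2.9-fold higher number from compound 2 to compound 3 (0.46 log units; beyond the scatter). In this assay compound 3 is estimated at 20 nM, expected to fall between 5 nM and 80 nM.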

Compound 3, inhibition constant: 7 nM
Compound 3: middle estimate off by 2.9-fold (0.46 log units), on the high side; the range from low to high includes it.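

Going by these compounds alone, this is the first step that changes a single place, and it gives no change at the digits printed from compound 2 to compound 3 (within the scatter) in this assay. The end of this propyl chain therefore takes cyano, with 2 heavy atoms and 1 hydrogen-bond acceptor, in place of methyl, with 1 heavy atom and no hydrogen-bond acceptor, and the read-out does not move beyond the usual scatter. Nothing shown here offers a measured reason for this outcome.

Going by these compounds, whether the same place would also take an amine, a carboxylic acid or a longer chain remains open, since one step describes one replacement only. On these data alone, it is also open whether cyano in place of methyl on the other propyl chain would give a similar result.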